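Exchanging an acetamido end for 4-methoxybenzyl

The source may report more compounds than this note shows. Statements on the series, on what has been measured and on what is new or still open speak of the compounds shown alone.

In a functional assay on SW-620 cells (Homo sapiens) for inhibition, read by MTT assay, with a stated time of 72 h (on this read-out lower numbers stand for stronger inhibition and higher numbers for weaker inhibition), compound 1 `COc1ccc(CNCc2c(OC)cc(Oc3cccc(Nc4ccccc4)c3)cc2OC)cc1` gives 6970 nM, compound 2 `COc1ccc(CCCNCc2c(OC)cc(Oc3ccc(Nc4ccccc4)cc3)cc2OC)cc1` gives 14600 nM and compound 3 `COc1cc(Oc2cccc(Nc3ccccc3)c2)cc(OC)c1CNCCNC(C)=O` gives 11900 nM. Compound 3 thus lies within the scatter of both other compounds. Compound 4 `COc1ccc(CCCNCc2c(OC)cc(Oc3cccc(Nc4ccccc4)c3)cc2OC)cc1` keeps the core of compound 3 but carries 4-methoxybenzyl in place of acetamido on a saturated chain carbon, two bonds along the chain from an amine nitrogen. The closest measured change is a 1.7-fold higher number from compound 1 to compound 3 (0.23 log units; within the scatter), where acetamidomethyl replaces 4-methoxyphenyl, and it stays within the scatter. Compound 2 bears the same 3-(4-methoxyphenyl)propyl group on its own core and gives 14600 nM, which also points to no large shift. No change beyond the scatter is therefore expected in this assay. The expected step is a 1.2-fold lower number from compound 3 to compound 4 (0.08 log units; within the scatter). Compound 4 is estimated at 10000 nM, with an expected range of 4500 nM to 22000 nM.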

Compound 4, half-maximal inhibitory concentration: 6400 nM
Compound 4: the middle estimate sits 1.6-fold (0.19 log units) above what was measured; low and high end bracket the measured number.
By their numbers in this assay, from the lowest: compounds 4, 1, 3 and 2 (each within the scatter of the next, the first and the last beyond it).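

In this assay the exchange of acetamido for 4-methoxybenzyl on this saturated chain carbon gives a 1.9-fold lower number from compound 3 to compound 4 (0.27 log units; within the scatter) and so stays within the scatter, although a group with no ring gives way to one with a six-membered aromatic ring of carbon only. The 4-methoxyphenyl end can also sit further along the chain without a step beyond the scatter, as 2-(4-methoxyphenyl)ethyl in place of 4-methoxyphenyl gives a 1.1-fold lower number from compound 1 to compound 4 (0.04 log units; within the scatter) and the two numbers cannot be told apart. Nothing measured here offers an explanation for these values.

The compounds shown leave open whether an end group of another kind, such as a carboxylic acid or a primary amine, would move the number beyond the scatter at this position. They also leave open whether a longer chain carrying the 4-methoxyphenyl end would do so.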